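Replacing 2-methoxyphenyl with prop-1-en-1-yl on a double-bonded chain

The source may report more compounds than this note shows. Statements on the series, on what has been measured and on what is new or still open speak of the compounds shown alone.

Of the compounds shown here, three sharing one core have been measured in an ADME assay on HepG2 2.2.15 cells (Homo sapiens) for cytotoxicity (a higher number here means that more compound is tolerated, a lower number that less compound is tolerated), so far. Compound 1 (`O=CCc1c(-c2ccccc2Cl)c2cc(Cl)ccc2[nH]c1=O`) gives 120000 nM there, compound 2 (`COCC(=O)OCCc1c(-c2ccccc2Cl)c2cc(Cl)ccc2[nH]c1=O`) gives 74000 nM there, and compound 3 (`COc1ccccc1/C=C/C(=O)OCCc1c(-c2ccccc2Cl)c2cc(Cl)ccc2[nH]c1=O`) gives 770000 nM there. Compound 3 thus has the highest number of the three, meaning that cells tolerate the most of it.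

The next compound is compound 4 (`C/C=C/C=C/C(=O)OCCc1c(-c2ccccc2Cl)c2cc(Cl)ccc2[nH]c1=O`), which has not yet been measured. It differs from compound 3 at one place only (prop-1-en-1-yl in place of 2-methoxyphenyl on a double-bonded chain carbon bound to a double-bonded chain carbon): prop-1-en-1-yl stands in place of 2-methoxyphenyl on a double-bonded chain carbon bound to a double-bonded chain carbon.

Two measured steps offer guidance. Putting (((methoxymethyl)carbonyl)oxy)methyl in place of formyl gave a 1.6-fold lower number from compound 1 to compound 2 (0.21 log units; within the scatter) and says little here. More relevant is the change at the same end of the molecule, 2-(2-methoxyphenyl)ethenyl in place of methoxymethyl, which gave a 10-fold higher number from compound 2 to compound 3 (1.02 log units; beyond the scatter) as the large step. Compound 4 keeps a double bond there but loses the aromatic ring, so part of that rise is expected to disappear in this assay as a move to a lower number. The expected step is a 3.9-fold lower number from compound 3 to compound 4 (0.59 log units; beyond the scatter) on this estimate. For compound 4 the estimated value is 200000 nM with an expected range from 70000 nM to 650000 nM.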

Compound 4, half-maximal cytotoxic concentration: 440000 nM
Compound 4: middle estimate off by 2.2-fold (0.34 log units), on the low side; the range from low to high includes it.
By their numbers in this assay, from the lowest: compounds 2 and 1 (each within the scatter of the next); then compounds 4 and 3 (each within the scatter of the next).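

In this assay, prop-1-en-1-yl in place of 2-methoxyphenyl gave a 1.8-fold lower number from compound 3 to compound 4 (0.24 log units; within the scatter), so in this place the aromatic ring and its methoxy group can be exchanged for a short unsaturated chain without a change that stands out from the scatter. The rise seen earlier on the carbonyl carbon therefore does not need an aromatic ring: penta-1,3-dien-1-yl in place of methoxymethyl gave a 5.9-fold higher number from compound 2 to compound 4 (0.77 log units; beyond the scatter), and the whole penta-1,3-dien-1-yl ester in place of formyl gave a 3.7-fold higher number from compound 1 to compound 4 (0.56 log units; beyond the scatter). Compound 3 and compound 4 both carry a double-bonded chain on that carbonyl carbon, while compound 2 carries methoxymethyl there, but no measurement at hand says why cells tolerate these compounds differently.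

As far as these compounds go, whether the double bonds matter, or only the carbon chain, remains open, and a saturated pentyl chain on the carbonyl carbon would separate those two readings. Also open, from the compounds shown here alone, is how this assay would respond to an amine or a carboxylic acid in place of prop-1-en-1-yl.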